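Changing One Side Chain of Compound 3 Against Calpain-1

A few compounds are considered here, and "the series" means these few. Any claim that something is new, unique, unknown or untested is made for them only; others in the source may bear on it.

Of the compounds shown here, three sharing one core have been measured in an assay on isolated protein for inhibition of Calpain-1 catalytic subunit (Homo sapiens), read by fluorescence, with a stated time of 60 min, tested at 1 uM; on this read-out lower numbers stand for less inhibition and higher numbers for more inhibition at the one concentration tested (going by the name of the read-out). Compound 1 `COCCN/C(=C1/N=CN(CCOC)C1=O)c1cc2ccccc2[nH]1` gives 73.7%. Compound 2 `CCCCN/C(=C1/N=CN(CCCC)C1=O)c1cc2ccccc2[nH]1` gives 14%. Compound 3 `CCCCN/C(=C1/N=CN(CCOC)C1=O)c1cc2ccccc2[nH]1` gives 75.4%, the highest of the three numbers, although compound 1 sits within the scatter of it and only compound 2 lies clearly below.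

Two single-point steps lead to compound 3. The step of a number 1.7 percentage points higher from compound 1 to compound 3 (within the scatter) shows that altering the chain on the amine nitrogen side barely moved the read-out. The step of a number 61.4 percentage points higher from compound 2 to compound 3 (beyond the scatter) shows that the chain on the ring nitrogen matters a great deal.

Compound 4 `COCCN1C=N/C(=C(/NCCN(C)C)c2cc3ccccc3[nH]2)C1=O` keeps the ring-nitrogen chain of compound 3 unchanged and differs only by dimethylamino in place of ethyl on a saturated chain carbon, two bonds along the chain from an amine nitrogen. For the measured compounds named here, the step that bears on this is the one from compound 1 to compound 3, since it too altered the chain on the amine nitrogen, and it stayed within the scatter. The change to dimethylamino brings a new hydrogen-bond acceptor, so some shift is possible, but nothing measured here supports a large one. Compound 4 is therefore expected to land near compound 3, with an estimated step of a number 5.4 percentage points lower from compound 3 to compound 4 (within the scatter), giving an expected value of 70% with a range from 45% to 88%.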

Compound 4, a percentage reported as inhibition, at one concentration (the size of the read-out at that concentration, not a potency): 64.6%
The estimate for compound 4 lay 5.4 percentage points above the measured number; low and high end bracket the measured number.
By their numbers in this assay, from the lowest: compound 2; then compounds 4, 1 and 3 (each within the scatter of the next, the first and the last beyond it).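

For the compounds shown here, on a saturated chain carbon, two bonds along the chain from an amine nitrogen, the step of a number 10.8 percentage points lower from compound 3 to compound 4 (beyond the scatter) is the first change at this place to pass the usual spread of repeat measurements in this assay and so shows that the group here can affect the read-out. The step of a number 9.1 percentage points lower from compound 1 to compound 4 (within the scatter) does not pass that spread, so dimethylamino can be told apart from ethyl at this place but not from methoxy, and the effect remains much smaller than the step of a number 61.4 percentage points higher from compound 2 to compound 3 (beyond the scatter) seen when the chain on the ring nitrogen changed. No other measurement accompanies these numbers to explain the shift from ethyl to dimethylamino.

The compounds shown leave open whether a longer chain ending in dimethylamino, a ring amine such as morpholine, or a carboxylic acid at this place would keep the read-out or lower it further. With only one tested concentration, they also leave open whether the small differences among these compounds would hold up in a full measurement of potency.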